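Swapping the Anilide Ring for a Chloropyridyl Amide

The source may hold more compounds than are shown below. What is called first, only, known or untested is meant among the compounds shown, and "the series" means these compounds.

Measured compounds:
compound 1 `Cc1noc(C)c1-c1cnc(N)c(Oc2ccc(C(=O)Nc3ccccc3)cc2)n1`: 5740 nM
compound 2 `Cc1noc(C)c1-c1cnc(N)c(Oc2ccc(C(=O)Nc3cccc(Cl)c3)cc2)n1`: 1640 nM
compound 3 `Cn1cc(-c2cnc(N)c(Oc3ccc(C(=O)Nc4ccccc4)cc3)n2)cn1`: 9210 nM

All three were tested in a functional assay on LoVo cells (Homo sapiens) for inhibition, read by MTT assay, with a stated time of 72 h; a higher number here means a weaker inhibitor, a lower number a stronger inhibitor. Among them compound 3 gives the highest number. Compound 1 sits close to it, since a 1.6-fold higher number from compound 1 to compound 3 (0.21 log units; within the scatter), while compound 2 shows a clearly lower number than compound 3. For the measured compounds named here, the one step that changes the amide ring is a 3.5-fold lower number from compound 1 to compound 2 (0.54 log units; beyond the scatter), a modest gain from adding a chlorine to that ring.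

Compound 4 `Cn1cc(-c2cnc(N)c(Oc3ccc(C(=O)Nc4cccc(Cl)n4)cc3)n2)cn1` is the next compound to be measured. It differs from compound 3 in that (6-chloropyridin-2-yl in place of phenyl on an amide-type nitrogen). Going by the values given here, this change bundles two things: a chlorine enters the ring on the amide nitrogen, as it did from compound 1 to compound 2, and a ring carbon becomes a nitrogen, for which no measured pair gives guidance. Among the compounds with values here, the chlorine step seen between compound 1 and compound 2 is the only direct precedent, so a gain of similar modest size is expected, with wider uncertainty. The step from this change is estimated at a 2.6-fold lower number from compound 3 to compound 4 (0.42 log units; beyond the scatter). Compound 4 is therefore expected to give 3500 nM, within a range from 1200 nM to 10000 nM.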

Compound 4, half-maximal inhibitory concentration: 48600 nM
For compound 4 the middle estimate is 14-fold (1.14 log units) below the measured one; measured number outside the range, above it.
By their numbers in this assay, from the lowest: compound 2; then compounds 1 and 3 (each within the scatter of the next); then compound 4.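

The place on the amide-type nitrogen does not reward every chlorine-bearing ring, since in this assay the swap from phenyl to 6-chloropyridin-2-yl makes compound 4 a weaker inhibitor than compound 3 (a 5.3-fold higher number from compound 3 to compound 4 (0.72 log units; beyond the scatter)). Adding chlorine to the phenyl ring had moved the number the opposite way (a 3.5-fold lower number from compound 1 to compound 2 (0.54 log units; beyond the scatter)), so that earlier gain does not carry over to a change that also puts a nitrogen into the ring and that sits on a compound with a different group at the other end of the molecule, 1-methyl-1H-pyrazol-4-yl in place of 3,5-dimethyl-1,2-oxazol-4-yl. Nothing available explains this reversal.

The compounds shown leave open whether the loss comes from the ring nitrogen, from the chlorine in this new setting, or from the two together. Plain pyridin-2-yl on the amide-type nitrogen, or a chlorophenyl ring paired with the 1-methyl-1H-pyrazol-4-yl group, would each change only one thing and so help separate these possibilities.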